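A Single Fluorine Added to the Anilino Ring

The source may hold more compounds than are shown below. What is called first, only, known or untested is meant among the compounds shown, and "the series" means these compounds.

Compound 1 `Cc1cc(-c2cnn3c(NCC4CCOCC4)nc(NC4CCCC4)nc23)ccc1NC(=O)C1CC1`: "not determined" (no result reported)
Compound 2 `Cc1cc(-c2cnn3c(NCC4CCOCC4)nc(Nc4ccccc4)nc23)ccc1C(=O)NC1CC1`: 690 nM

Two compounds share a common core here. For compound 1 the entry in a functional assay on HCT-116 cells (Homo sapiens) for antiproliferative activity (on this read-out lower numbers stand for stronger inhibition of growth and higher numbers for weaker inhibition of growth), reads "not determined" (no result reported), so it contributes no number. Within the data shown here, compound 2 is therefore the only compound with a measured value, and in this assay compound 2 gives 690 nM; with nothing to compare against, it stands alone rather than high or low.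

Compound 3 `Cc1cc(-c2cnn3c(NCC4CCOCC4)nc(Nc4ccccc4F)nc23)ccc1C(=O)NC1CC1` differs from compound 2 in one place: fluoro in place of hydrogen on an aromatic carbon. The fluoro group enters on an aromatic carbon of the anilino ring, ortho to a large group. Among the measured compounds shown here, with no measured pair available to show what such a change does on this core, the step is expected to be small, likely within the usual scatter, with no clear direction. On that basis the step from compound 2 to compound 3 in this assay is estimated at a 1.2-fold lower number from compound 2 to compound 3 (0.06 log units; within the scatter). Compound 3 is expected to give 600 nM, with a range of 220 nM to 1700 nM.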

Compound 3, concentration for 50% growth inhibition: 21 nM
Estimate against measurement, compound 3: 29-fold (1.46 log units) above; the measured number lies below the stated range.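

In this assay the anilino ring proves to be a sensitive part of this series: the change to (2-fluorophenyl)amino, with fluoro on an aromatic carbon ortho to a large group, is a 33-fold lower number from compound 2 to compound 3 (1.52 log units; beyond the scatter) and so counts as a large step. A lone value on the shared core could not show how much any one position matters, whereas this pair shows that adding a single heavy atom can shift growth inhibition strongly. Nothing at hand bears on why this step is so large.

The compounds shown carry only hydrogen or fluoro at this position, so it remains open whether chloro, methyl or methoxy there would have a similar effect. Also open, on these data alone, is whether fluoro on another carbon of the anilino ring would match this result.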